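A sulfonyl change and cytotoxicity in HEK-293T cells

A few compounds are considered here, and "the series" means these few. Any claim that something is new, unique, unknown or untested is made for them only; others in the source may bear on it.

Values from an ADME assay on HEK-293T cells (Homo sapiens) for cytotoxicity, read by MTT assay, with a stated time of 24 h (on this read-out lower numbers stand for higher toxicity in this test and higher numbers for lower toxicity in this test), so far:
Compound 1 `Cc1ccc(-c2nn(-c3ccccc3)cc2-c2nc3ccccc3n2S(=O)(=O)c2ccc(F)cc2)cc1` gives 128000 nM
Compound 2 `Cc1ccc(C)c(S(=O)(=O)n2c(-c3cn(-c4ccccc4)nc3-c3ccc(C(F)(F)F)cc3)nc3ccccc32)c1` gives 223000 nM

Compound 2 stands within the usual scatter of compound 1, so the two numbers cannot be told apart. Compound 3 `O=S(=O)(c1ccc(F)cc1)n1c(-c2cn(-c3ccccc3)nc2-c2ccc(C(F)(F)F)cc2)nc2ccccc21` has not yet been measured. It differs from compound 2 by 4-fluorophenyl in place of 2,5-dimethylphenyl on a sulfonyl sulfur and carries 4-fluorophenyl in place of 2,5-dimethylphenyl on a sulfonyl sulfur. Among the compounds with values here, no measured pair shows this change alone, so the data offer no direct step to go by. Within the data shown here, with compound 1 at 128000 nM and compound 2 at 223000 nM as the only guides, no shift beyond the scatter is expected in this assay for this change. The estimated change is a 1.3-fold lower number from compound 2 to compound 3 (0.12 log units; within the scatter) and would stay within the scatter. Compound 3 is estimated at 170000 nM with an expected range from 90000 nM to 320000 nM as the likely outcome.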

Compound 3, half-maximal cytotoxic concentration: 157000 nM
The estimate for compound 3 lay 1.1-fold (0.03 log units) above the measured number; the measured number falls inside the stated range.
By their numbers in this assay, from the lowest: compounds 1, 3 and 2 (each within the scatter of the next).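

In this assay, within the data shown here, 4-fluorophenyl in place of 2,5-dimethylphenyl on a sulfonyl sulfur gives a 1.4-fold lower number from compound 2 to compound 3 (0.15 log units; within the scatter) in the one pair that shows this change alone, so this swap at this position leaves the two numbers indistinguishable. Compound 3 also gives a second single-place comparison, where trifluoromethyl in place of methyl on an aromatic carbon gives a 1.2-fold higher number from compound 1 to compound 3 (0.09 log units; within the scatter) and again leaves the two compounds indistinguishable in this assay. No measured evidence bears on the reason for either result.

The compounds shown carry only substituted phenyl groups on the sulfonyl sulfur. As far as these compounds go, it remains open whether a methyl group or a longer alkyl chain in their place, or an amine or a carboxylic acid on that phenyl ring, would move the number beyond the scatter.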